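The source may report more compounds than this note shows. Statements on the series, on what has been measured and on what is new or still open speak of the compounds shown alone.

In an ADME assay (liver) for metabolic stability, with Liver microsome (Homo sapiens) as the target, using microsomes (a higher number here means faster removal of the compound, a lower number slower removal), two compounds of this series have been measured: compound 1 (`O=C(C1CC12CCN(C1CCOCC1)CC2)N1CCN(C2CC2)CC1`) and compound 2 (`O=C(C1CC2(CCN(C3CCOCC3)CC2)C1)N1CCN(C2CCC2)CC1`). Compound 1 gives < 4 mL.min-1.g-1, which is a limit of the assay and not a number. Compound 2 gives < 4 mL.min-1.g-1, which is likewise a limit and not a number. Compound 2 therefore has no exact position, and all that can be said of the two results is that they share (the limit of < 4 mL.min-1.g-1 in this assay, at which 2 of the 2 values shown sit). Compound 3 (`CC(C)N1CCN(C(=O)C2CC3(CCN(C4CCOCC4)CC3)C2)CC1`) keeps the rest of compound 2 but has isopropyl in place of cyclobutyl on an amine nitrogen in a ring. Among the compounds with values here, no measured pair differs in one place, so the size of this change has no direct precedent. The expectation rests on compound 2, which reads < 4 mL.min-1.g-1, again a limit. The estimated step of a number no lower from compound 2 to compound 3 (the limit leaves the size open) is expected to go no further than the scatter, in no particular direction in this assay. Compound 3 is expected at 4 mL.min-1.g-1, with an estimated range from 2 mL.min-1.g-1 to 8 mL.min-1.g-1.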

Compound 3, intrinsic clearance in microsomes in the Liver microsome assay: < 4 mL.min-1.g-1
Compound 3 ended at the assay's limit; the forecaster's own chance of this, stated with the estimate: 65%; the middle value lies on the limit itself.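

In the Liver microsome assay compound 2 gives < 4 mL.min-1.g-1, which is a limit of the assay and not a number. In the Liver microsome assay compound 3 gives < 4 mL.min-1.g-1, which is likewise a limit of the assay and not a number. In the Liver microsome assay no step can be read between compound 2 and compound 3, as the results of both are limits of the assay and not numbers: the limit of < 4 mL.min-1.g-1 in the Liver microsome assay, at which 3 of the 3 values shown sit. The compounds shown leave open how the clearance of these compounds truly compares in the Liver microsome assay, since none of them has a readable number there. In a physicochemical assay for lipophilicity, read by HPLC, using the shake flask method, measured as octanol-water partition (a lower number here means a more polar compound, a higher number a more lipophilic compound), compound 2 gives "not determined" (no result reported) and compound 3 gives -0.74, so the two cannot be compared there.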